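This account rests on a few compounds, and the source may have more. Where it says the series, first, only, none or still open, it means among the compounds named here.

Measured so far in a functional assay on BMMC cells (Mus musculus, strain C57BL/6) for inhibition, with stated times of 5 days and 48 h; on this read-out lower numbers stand for stronger inhibition and higher numbers for weaker inhibition:
compound 1, `C=C1CC[C@@H]2[C@](C)(CO)[C@H](O)CC[C@@]2(C)[C@@H]1C/C=C1\C=COC1=O`: 2770 nM
compound 2, `C=C1CC[C@@H]2[C@](C)(CNCc3ccc(OC)c(OC)c3)[C@H](O)CC[C@@]2(C)[C@@H]1/C=C/C1=CCOC1=O`: 3740 nM

In this assay compound 2 gives 3740 nM. Of the numbers in hand this is the higher one, yet compound 1 with 2770 nM lies within the usual scatter of it, so the two are not separable on this read-out and no order between them can be claimed. Within the data shown here, no pair of measured compounds differing in a single place is available, so the series offers no measured step to lean on.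

Compound 3, `C=C1CC[C@@H]2[C@](C)(CNCc3ccc([N+](=O)[O-])cc3)[C@H](O)CC[C@@]2(C)[C@@H]1/C=C/C1=CCOC1=O`, remains to be measured in this assay. It differs from compound 2 as follows: 4-nitrophenyl in place of 3,4-dimethoxyphenyl on a saturated chain carbon bound to an amine nitrogen. The rest of the shared core, the amine linkage and the lactone side are untouched.

With no measured step of this kind in the series, the expectation for compound 3 is a step within the scatter, neither clearly stronger nor clearly weaker than compound 2, expected as a 1.1-fold lower number from compound 2 to compound 3 (0.03 log units; within the scatter). Compound 3 is therefore estimated at 3500 nM in this assay, with a range from 1200 nM to 10000 nM.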

Compound 3, half-maximal inhibitory concentration: 1340 nM
Estimate against measurement, compound 3: 2.6-fold (0.42 log units) above, and the stated range covers the measured number.
By their numbers in this assay, from the lowest: compound 3; then compounds 1 and 2 (each within the scatter of the next).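

In this assay the series now has its first measured step at the aromatic group on a saturated chain carbon bound to an amine nitrogen: 4-nitrophenyl in place of 3,4-dimethoxyphenyl gives a 2.8-fold lower number from compound 2 to compound 3 (0.45 log units; beyond the scatter) in a pair whose amine linkage, lactone side and remaining shared core are the same. The read-out therefore responds to a change at this position, although the step is modest in size and rests on one pair. No measurement at hand accounts for the step, and it cannot be tied to any property of either group.

The change removes the methoxy groups and brings in the nitro group at once, so the compounds shown do not tell whether the step follows from what leaves, from what enters, or from both. An unsubstituted phenyl, a 4-methoxyphenyl or a 4-aminophenyl at the same place would separate these contributions, and a 4-carboxyphenyl would show how far the position tolerates a quite different group.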